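Aryl replacement on the shared core: outlook for compound 4

The compounds below may be only part of what the source reports. "The series", "measured", "known", "first", "only" and "open" are said of these compounds alone.

Measured in a functional assay on MCF7 cells (Homo sapiens) for cytotoxicity, read by MTT assay, with a stated time of 96 h; a higher number here means a weaker inhibitor, a lower number a stronger inhibitor:
compound 1 `COc1cc(C(=O)c2cn(-c3ccccc3)cc2-c2ccc(N)cc2)cc(OC)c1OC` — 9 nM
compound 2 `COc1cc(C(=O)c2cn(-c3ccccc3N)cc2-c2ccccc2)cc(OC)c1OC` — 3800 nM
compound 3 `COc1ccc(-n2cc(C(=O)c3cc(OC)c(OC)c(OC)c3)c(-c3ccccc3)c2)cc1` — 120 nM

Compound 1 gives the lowest number of the three in this assay; compound 3 is nearest to it and compound 2 furthest, both beyond the scatter. Going by the values given here, the only step between compounds differing in one place is a 32-fold lower number from compound 2 to compound 3 (1.50 log units; beyond the scatter), a change of the group on the aromatic nitrogen. Compound 1 and compound 3 differ in two places, so their values show only that the two arrangements are far apart.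

Compound 4 `COc1ccc(Br)cc1-c1cn(-c2ccccc2)cc1C(=O)c1cc(OC)c(OC)c(OC)c1` differs from compound 1 by 5-bromo-2-methoxyphenyl in place of 4-aminophenyl on an aromatic carbon. Among the compounds with values here, this change sits on an aromatic carbon, a position no measured step covers; the nitrogen-side step shows that the aryl groups of this series move the number a great deal, but it does not bear directly on the carbon side. Since the 4-aminophenyl of compound 1 accompanies the lowest number, the expectation is a rise, estimated as a 28-fold higher number from compound 1 to compound 4 (1.44 log units; beyond the scatter). Compound 4 is therefore estimated at 250 nM in this assay, within 40 nM to 1600 nM.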

Compound 4, half-maximal inhibitory concentration: 2200 nM
Compound 4: middle estimate off by 8.8-fold (0.94 log units), on the low side; measured number above the stated range.
By their numbers in this assay, from the lowest: compound 1; then compound 3; then compounds 4 and 2 (each within the scatter of the next).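

In this assay, the aromatic carbon two ring bonds from the ring nitrogen now has a measured step: a 240-fold higher number from compound 1 to compound 4 (2.39 log units; beyond the scatter), with 5-bromo-2-methoxyphenyl in place of 4-aminophenyl. Aryl replacement on this carbon therefore moves the number beyond the scatter, as the change on the aromatic nitrogen does in a 32-fold lower number from compound 2 to compound 3 (1.50 log units; beyond the scatter). The exchange removes the amine and brings in the methoxy and the bromine together, and nothing at hand accounts for the rise.

Still open, going by these compounds, is which part of the exchange carries the step: a 2-methoxyphenyl, a 3-bromophenyl or a 4-hydroxyphenyl on this carbon would separate the three changes. Also open, on these data alone, is how a 4-(dimethylamino)phenyl here would compare with the 4-aminophenyl of compound 1.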